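Dichlorophenyl Replaces Methyl on the Ring Nitrogen Substituent

The compounds below may be only part of what the source reports. "The series", "measured", "known", "first", "only" and "open" are said of these compounds alone.

Measured so far:
- compound 1, `CCOC(=O)/C=C/c1ccc2c(c1)C(=O)C(=O)N2Cc1ccc(OC)cc1`: in a functional assay on HT-29 cells (Homo sapiens) for cytotoxicity, read by MTT assay, with a stated time of 48 h (on this read-out higher numbers stand for weaker inhibition and lower numbers for stronger inhibition), compound 1 gives 60 nM
- compound 2, `CCN1C(=O)C(=O)c2cc(/C=C/C(=O)OC)ccc21`: in this assay compound 2 gives 210 nM

Among the compounds with values here, compound 2 has the higher of the two numbers, and its gap to compound 1 lies beyond the usual scatter of this assay; since the two differ in more than one place, no single step between them is described. Compound 3, `COC(=O)/C=C/c1ccc2c(c1)C(=O)C(=O)N2Cc1ccc(Cl)c(Cl)c1`, has not yet been measured. It arises from compound 2 by one change: 3,4-dichlorophenyl in place of methyl on a saturated chain carbon bound to an amide-type nitrogen in a ring. Compound 1 likewise carries a six-membered aromatic ring of carbon only on that saturated chain carbon, and compound 1 gives 60 nM, which lies below the number for compound 2. Whether the two chlorines behave like the group in compound 1 cannot be read from these two values alone. On this basis, the step from compound 2 to compound 3 is expected to be a decrease in the number, a 3.0-fold lower number from compound 2 to compound 3 (0.48 log units; beyond the scatter). Compound 3 is therefore estimated at 70 nM, with a range from 25 nM to 200 nM.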

Compound 3, half-maximal inhibitory concentration: 210 nM
For compound 3 the middle estimate is 3.0-fold (0.48 log units) below the measured one; the measured number lies above the stated range.
By their numbers in this assay, from the lowest: compound 1; then compounds 2 and 3 (each within the scatter of the next).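

In this assay the swap of methyl for 3,4-dichlorophenyl gives no change at the digits printed from compound 2 to compound 3 (within the scatter) on a saturated chain carbon bound to an amide-type nitrogen in a ring. Within the data shown here, this is the first single-place step, and it shows that this place takes a group of 8 heavy atoms with a six-membered aromatic ring instead of a single carbon, with no visible change in the read-out. Nothing at hand gives a measured reason for this flat step.

The compounds shown leave open what the ring and its two chlorines each contribute, since a plain phenyl, or a ring carrying an amine or a carboxylic acid, at this place would be needed to separate them. From the compounds shown here alone, it also stays open how the lower number of compound 1 arises: compound 1 differs from compound 3 in more than one place, in both the ester and the groups on the aromatic ring, so the two cannot be read as a single step.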